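A few compounds are considered here, and "the series" means these few. Any claim that something is new, unique, unknown or untested is made for them only; others in the source may bear on it.

Measured so far in an ADME assay on microsomes from liver (Homo sapiens), read by LC-MS, using NADPH, with a stated time of 30 min, tested at 1 uM; a lower number here means that less of the compound is left, a higher number that more of the compound is left: compound 1 `Cc1cccc(-c2c([C@H](C)Nc3nc(N)nc(N)c3C#N)cc3ccc(F)cn3c2=O)c1` gives 89%; compound 2 `Cc1cc(F)cc(-c2c([C@H](C)Nc3nc(N)nc(N)c3C#N)cc3ccc(F)cn3c2=O)c1` gives 80%; compound 3 `C[C@H](Nc1ncnc(N)c1C#N)c1cc(=O)n2cc(F)ccc2c1-c1cccc(F)c1` gives 87%.

Compound 2 differs from compound 1 by fluoro in place of hydrogen on an aromatic carbon, and that change gave a number 9 percentage points lower from compound 1 to compound 2 (within the scatter). Compound 4 `C[C@H](Nc1ncnc(N)c1C#N)c1cc(=O)n2cc(F)ccc2c1-c1cc(F)cc(F)c1`, not yet measured, differs from compound 3 by fluoro in place of hydrogen on an aromatic carbon. This is the same kind of change: in compound 1 the new fluoro sits meta to a methyl group, in compound 3 it sits meta to a fluoro group. The difference between the two cores of compound 1 and compound 3 is not broken down here. Because compound 1 to compound 2 gave a number 9 percentage points lower from compound 1 to compound 2 (within the scatter), a step of similar size is expected, a number 7 percentage points lower from compound 3 to compound 4 (within the scatter). Compound 4 is therefore estimated at 80%, expected between 66% and 92%.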

Compound 4, percent of the compound remaining: 91%
Beside the measured number, compound 4's estimate is 11 percentage points below it; low and high end bracket the measured number.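

In this assay, fluoro in place of hydrogen on an aromatic carbon, here 3-fluorophenyl to 3,5-difluorophenyl, gave a number 4 percentage points higher from compound 3 to compound 4 (within the scatter). Set beside the earlier case, the two steps do not differ by more than repeated measurement allows: the same change on two cores in this assay, a number 9 percentage points lower (within the scatter) from compound 1 to compound 2 and a number 4 percentage points higher (within the scatter) from compound 3 to compound 4, 13 percentage points apart, within the scatter of two such steps. The two pairs are therefore compatible with the change carrying from one core to the other, but with both steps inside the scatter they do not show that fluoro has any effect of its own on either core, or that the two cores respond alike.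

The compounds shown leave open how chloro, methoxy or an amine in the same place would read. Cores beyond these two also remain open.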